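This account rests on a few compounds, and the source may have more. Where it says the series, first, only, none or still open, it means among the compounds named here.

Series notes. In a functional assay on CHO cells for agonist activity at Free fatty acid receptor 1 (Homo sapiens), read by FLIPR and calcium flux (on this read-out lower numbers stand for an effect already at smaller amounts and higher numbers for an effect only at larger amounts of compound), compound 3 `Cc1ccccc1-c1cccc(CNc2ccc(OCC(=O)O)c(F)c2)c1` gives 4.8 nM, the lowest of the two numbers in hand. Compound 1 `CCOc1cc(C)c(-c2cccc(CNc3ccc(OCC(=O)O)c(F)c3)c2)c(C)c1` gives 24.2 nM in this assay, a gap beyond the scatter. For compound 2 `CCOc1cc(C)c(-c2cccc(COc3ccc(NCC(=O)O)c(F)c3)c2)c(C)c1` this assay reports only a limit, > 1000 nM, not a number (the limit of > 1000 nM in this assay, at which 1 of the 3 values shown sits). Compound 4 `CCOc1ccc(-c2cccc(CNc3ccc(OCC(=O)O)c(F)c3)c2)c(C)c1` is not yet measured and differs from compound 3 by ethoxy in place of hydrogen on an aromatic carbon, the ethoxy entering on an aromatic carbon of the six-membered carbon ring, meta to a methyl group and para to a large group. Among the measured compounds shown here, no single-change step between measured compounds is in hand, so the size of this effect is unknown from the data. The expected step is modest, toward a higher number: a 2.1-fold higher number from compound 3 to compound 4 (0.32 log units; beyond the scatter). Compound 4 is estimated at 10 nM, within 3 nM to 30 nM.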

Compound 4, half-maximal effective concentration: 11.6 nM
The estimate for compound 4 lay 1.2-fold (0.06 log units) below the measured number; measured number inside the range.
By their numbers in this assay, from the lowest: compound 3; then compound 4; then compound 1. At a limit, above all of these: compound 2.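

In this assay, among the compounds shown here, the 2-methylphenyl to 4-ethoxy-2-methylphenyl change gives the first single-change reading at this position: a 2.4-fold higher number from compound 3 to compound 4 (0.38 log units; beyond the scatter). The second methyl of compound 1 can now be read separately, as a 2.1-fold lower number from compound 1 to compound 4 (0.32 log units; beyond the scatter), so both added groups go with a higher number and each step is modest. No measurement in hand bears on the cause of either step.

From the compounds shown here alone, whether methoxy, a hydroxyl, an amine or a longer ether chain at the ethoxy position would give a lower or a higher number stays open.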